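The source may report more compounds than this note shows. Statements on the series, on what has been measured and on what is new or still open speak of the compounds shown alone.

Measured so far in a functional assay on NCI-H1581 cells (Homo sapiens) for inhibition, read by MTT assay, with a stated time of 48 h, tested at 10 uM; a lower number here means less inhibition, a higher number more inhibition at the concentration tested (going by the name of the read-out):
compound 1, `COc1cc(NC(=O)Nc2cc(Nc3ccc(C(C)(C)C)cc3)ncn2)cc(OC)c1`, gives 38.7%
compound 2, `COc1cc(NC(=O)Nc2cc(Nc3ccc(C)c(F)c3)ncn2)cc(OC)c1`, gives 38%
compound 3, `O=C(Nc1cc(Nc2ccc(F)c(Cl)c2)ncn1)Nc1c(Cl)cccc1Cl`, gives 67%

Going by the values given here, compound 2 holds the smallest of the three numbers, but the step of a number 0.7 percentage points lower from compound 1 to compound 2 (within the scatter) lies within the scatter, so compound 1 and compound 2 cannot be told apart; only compound 3 stands clearly higher, and it differs from compound 2 in two places, so no single step links them.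

Compound 4, `COc1cc(NC(=O)Nc2cc(Nc3ccc(Br)cc3OC)ncn2)cc(OC)c1`, is not yet measured. It arises from compound 2 by 4-bromo-2-methoxyphenyl in place of 3-fluoro-4-methylphenyl on a nitrogen on an aromatic ring. Among the compounds with values here, the one step that bears on it is the aryl swap on the same nitrogen, a number 0.7 percentage points lower from compound 1 to compound 2 (within the scatter), which was within the scatter. With only that to go on, a step beyond the scatter is not expected in this assay in either direction, and the expected step is no change at the digits printed from compound 2 to compound 4 (within the scatter).

For compound 4 the estimated value in this assay is 38%, expected to fall between 24% and 54%.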

Compound 4, a percentage reported as inhibition, at one concentration (the size of the read-out at that concentration, not a potency): 20.1%
For compound 4 the middle estimate is 17.9 percentage points above the measured one, and the stated range ends above it.
By their numbers in this assay, from the lowest: compound 4; then compounds 2 and 1 (each within the scatter of the next); then compound 3.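

In this assay the aryl group on a nitrogen on an aromatic ring turns out to be able to shift the number: the earlier swap here, a number 0.7 percentage points lower from compound 1 to compound 2 (within the scatter), did not do so. With 4-bromo-2-methoxyphenyl entering, the change reads a number 17.9 percentage points lower from compound 2 to compound 4 (beyond the scatter) when it replaces 3-fluoro-4-methylphenyl and a number 18.6 percentage points lower from compound 1 to compound 4 (beyond the scatter) when it replaces 4-(tert-butyl)phenyl, and both steps lie beyond the scatter. This place is therefore not indifferent to the aryl group, and the change lowers the inhibition read at the tested concentration, whichever of these two groups it replaces. No measurement at hand speaks to the reason for this drop.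

The bromo and methoxy groups enter together, so the compounds shown do not separate their contributions. From the compounds shown here alone, how a carboxylic acid or a morpholine on this phenyl ring would read remains open.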